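A few compounds are considered here, and "the series" means these few. Any claim that something is new, unique, unknown or untested is made for them only; others in the source may bear on it.

Compound 1 `COc1ccc(C(=O)/C=C/c2ccc(F)cc2)c2c1C=CC(C)(C)O2` shows no measurable inhibition within the tested range: in a functional assay on HepG2 cells (Homo sapiens) for antiproliferative activity, read by MTT assay, with a stated time of 24 h (on this read-out lower numbers stand for stronger inhibition and higher numbers for weaker inhibition), compound 1 gives > 10000 nM, a limit of the assay rather than a number. Compound 2 `COc1ccc(C(=O)/C=C/c2cccc(F)c2)c2c1C=CC(C)(C)O2` also reaches only a limit, giving > 10000 nM in this assay. The step that the two limits leave unreadable from compound 1 to compound 2 is therefore not readable, since both values sit on (the limit of > 10000 nM in this assay, at which 2 of the 2 values shown sit). Compound 3 `COc1ccc(C(=O)/C=C/c2ccc(Br)cc2)c2c1C=CC(C)(C)O2` carries 4-bromophenyl in place of 3-fluorophenyl on a double-bonded chain carbon bound to a double-bonded chain carbon. Going by the values given here, no measured step bears on this change, and compound 2 itself stands only at the limit. The expected step is a step that the limit leaves unreadable from compound 2 to compound 3, with a limit again the likeliest outcome. Compound 3 is estimated at 15000 nM, range 7000 nM to 40000 nM.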

Compound 3, half-maximal inhibitory concentration: > 10000 nM
Compound 3: only a limit was reported; the forecaster's own chance of this, stated with the estimate: 75%; the middle value does not contradict the limit.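

In this assay compound 3 gives > 10000 nM as a limit and not a number. Going by these compounds alone, no step among compound 1, compound 2 and compound 3 can be read. On these data alone, whether 4-fluorophenyl, 3-fluorophenyl and 4-bromophenyl differ at all on the shared core stays open.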